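This account rests on a few compounds, and the source may have more. Where it says the series, first, only, none or still open, it means among the compounds named here.

Measured so far:
- compound 1 `CC(C)(C)C(=O)N1Cc2c(NC(=O)C3CCNCC3)n[nH]c2C1(C)C`: 650 nM
- compound 2 `CC(C)(C)C(=O)N1Cc2c(NC(=O)c3cccnc3)n[nH]c2C1(C)C`: 690 nM
- compound 3 `CN1CCC(C(=O)N2Cc3c(NC(=O)C4CCC4)n[nH]c3C2(C)C)CC1`: 140 nM

In a functional assay on A2780 cells (Homo sapiens) for antiproliferative activity, read by fluorescence, with a stated time of 72 h (on this read-out higher numbers stand for weaker inhibition and lower numbers for stronger inhibition), compound 2 gives 690 nM. That places it level with compound 1 within the scatter, while compound 3 shows a lower number at 140 nM. Compound 3 differs from compound 2 in more than one place, so it says little about a single swap.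

The next compound is compound 4 `CC(C)(C)C(=O)N1Cc2c(NC(=O)c3ccc(F)cc3)n[nH]c2C1(C)C`. Its change from compound 2 is 4-fluorophenyl in place of pyridin-3-yl on a carbonyl carbon, with 4-fluorophenyl in place of pyridin-3-yl on a carbonyl carbon.

Among the measured compounds shown here, only one measured step bears on this position: a 1.1-fold higher number from compound 1 to compound 2 (0.03 log units; within the scatter). Exchanging piperidin-4-yl for pyridin-3-yl there left the number within the scatter, which suggests that the read-out tolerates change at this carbonyl carbon. For the measured compounds named here, no measured compound carries 4-fluorophenyl, however, so this evidence is thin. No shift beyond the scatter is therefore expected in this assay, in either direction.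

The expected change is a 1.3-fold lower number from compound 2 to compound 4 (0.10 log units; within the scatter). For compound 4 the estimated value is 550 nM, with an expected range from 220 nM to 1400 nM.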

Compound 4, half-maximal inhibitory concentration: 270 nM
Beside the measured number, compound 4's estimate is 2.0-fold (0.31 log units) above it; the range from low to high includes it.
By their numbers in this assay, from the lowest: compounds 3 and 4 (each within the scatter of the next); then compounds 1 and 2 (each within the scatter of the next).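

In this assay this carbonyl carbon proves less tolerant than the earlier swap suggested: that swap gave a 1.1-fold higher number from compound 1 to compound 2 (0.03 log units; within the scatter) and stayed within the scatter, whereas 4-fluorophenyl in place of pyridin-3-yl gives a 2.6-fold lower number from compound 2 to compound 4 (0.41 log units; beyond the scatter) and passes beyond it. The same group in place of piperidin-4-yl gives a 2.4-fold lower number from compound 1 to compound 4 (0.38 log units; beyond the scatter) and so stands apart, by a modest margin, from both earlier groups. No measurement here explains what sets 4-fluorophenyl apart from the other two groups.

Still open, as far as these compounds go, is whether the fluorine matters at all or whether a ring of carbon only is enough, a question that plain phenyl would address. It is also unknown whether chlorine or methoxy in place of the fluorine would move the number further in either direction.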